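The compounds below may be only part of what the source reports. "The series", "measured", "known", "first", "only" and "open" are said of these compounds alone.

Measured compounds in a functional assay on MCF7 cells (Homo sapiens) for cytotoxicity, read by MTT assay, with a stated time of 48 h; a lower number here means a stronger inhibitor, a higher number a weaker inhibitor:

compound 1, `CCCCCCCCCCCCCCCCCCNC(=O)[C@@H](N)[C@@H](C)O`, in this assay gives 27400 nM
compound 2, `CCCCCCCCCCCCCCNC(=O)[C@@H](NC(=O)c1ccco1)[C@@H](C)O`, in this assay gives 105000 nM
compound 3, `CCCCCCCCCCCCCCCCCCNC(=O)[C@@H](NC(=O)c1ccccc1)[C@@H](C)O`, in this assay gives 31800 nM

Compound 3 stands second highest of the three numbers. Compound 1 lies nearest, within the scatter, so no order between compound 1 and compound 3 can be read. Compound 2 lies furthest, at a higher number beyond the scatter. Within the data shown here, the only single-change step measured so far is a 1.2-fold higher number from compound 1 to compound 3 (0.06 log units; within the scatter), a change that lies within the scatter and does not touch the ring that is varied next.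

Compound 4, `CCCCCCCCCCCCCCCCCCNC(=O)[C@@H](NC(=O)c1ccco1)[C@@H](C)O`, is to be measured in this assay. It differs from compound 3 by furan-2-yl in place of phenyl on a carbonyl carbon. Among the measured compounds shown here, no measured step covers this change directly. Compound 2 carries the same furan-2-yl carbonyl group but on a shorter chain and so differs from compound 3 in two places; what its value shows is that the furan-bearing compound 2 returns the highest number of the three, beyond the scatter from compound 3. On that basis a rise in the number is expected for compound 4, of a size near the edge of the scatter, a 1.7-fold higher number from compound 3 to compound 4 (0.24 log units; within the scatter). Compound 4 is estimated at 55000 nM, with a range from 22000 nM to 140000 nM.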

Compound 4, half-maximal inhibitory concentration: 21400 nM
Compound 4: middle estimate off by 2.6-fold (0.41 log units), on the high side, and the stated range ends above it.
By their numbers in this assay, from the lowest: compounds 4, 1 and 3 (each within the scatter of the next); then compound 2.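

Furan-2-yl in place of phenyl on a carbonyl carbon gives a 1.5-fold lower number from compound 3 to compound 4 (0.17 log units; within the scatter) in this assay, so on the longer chain this ring change sets no order between the two amides. Among these compounds, with the (furan-2-yl)carbonyl group held fixed, butyl in place of hydrogen on a saturated chain carbon gives a 4.9-fold lower number from compound 2 to compound 4 (0.69 log units; beyond the scatter), the only step so far beyond the scatter, so the high number of compound 2 follows the chain and not the furan ring. Placing (furan-2-yl)carbonyl on the amine nitrogen gives a 1.3-fold lower number from compound 1 to compound 4 (0.11 log units; within the scatter), which like a 1.2-fold higher number from compound 1 to compound 3 (0.06 log units; within the scatter) lies within the scatter, so neither acyl group separates from the free amine on this chain.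

No evidence on hand bears on these results. On these data alone, whether a thiophene or pyridine ring on the carbonyl would separate from phenyl and furan-2-yl, and whether a longer chain would extend the chain step, remains open.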